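Swapping (naphthalen-1-yl)methyl for 3-fluorophenyl

A few compounds are considered here, and "the series" means these few. Any claim that something is new, unique, unknown or untested is made for them only; others in the source may bear on it.

In a functional assay on RS4-11 cells (Homo sapiens) for inhibition, read by CCK-8 assay, with a stated time of 48 h, tested at 20 uM (a lower number here means less inhibition of growth, a higher number more inhibition of growth at the concentration tested), compound 1 (`COc1ccc(S(=O)(=O)Oc2ccccc2/C=C(\C#N)C(=O)Nc2nnc(Cc3cccc4ccccc34)s2)cc1`) gives 78% of growth inhibition and compound 2 (`N#C/C(=C\c1ccccc1OS(=O)(=O)c1ccc(Cl)cc1)C(=O)Nc1nnc(Cc2cccc3ccccc23)s1`) gives 68% of growth inhibition, so the two stand within the scatter of each other. Among the measured compounds shown here, the only measured step is a number 10 percentage points lower from compound 1 to compound 2 (within the scatter) and it is chloro in place of methoxy, at another place in the molecule. Compound 3 (`N#C/C(=C\c1ccccc1OS(=O)(=O)c1ccc(Cl)cc1)C(=O)Nc1nnc(-c2cccc(F)c2)s1`) carries 3-fluorophenyl in place of (naphthalen-1-yl)methyl on an aromatic carbon with 3-fluorophenyl in place of (naphthalen-1-yl)methyl on an aromatic carbon. For the measured compounds named here, no measured step covers this change, so only a moderate, uncertain fall is expected. The estimated step is a number 13 percentage points lower from compound 2 to compound 3 (beyond the scatter) in this reading. For compound 3 the estimate is 55% with an expected range of 30% to 80% in this assay for now.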

Compound 3, percent growth inhibition at one concentration: 71%
The estimate for compound 3 lay 16 percentage points below the measured number, and the stated range covers the measured number.
By their numbers in this assay, from the lowest: compounds 2, 3 and 1 (each within the scatter of the next).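

In this assay the change to 3-fluorophenyl in place of (naphthalen-1-yl)methyl gives a number 3 percentage points higher from compound 2 to compound 3 (within the scatter) on this aromatic carbon of the five-membered aromatic ring. The earlier step concerned another place in the molecule, whereas this one shows growth inhibition staying within the scatter at this position while one six-membered aromatic ring leaves. No evidence on hand bears on this result.

Still open, as far as these compounds go, is how a non-aromatic group, such as an amine, a carboxylic acid or a longer chain, would read at this carbon. Also open, from the compounds shown here alone, is whether 3-fluorophenyl would give a similar reading with methoxy in place of chloro.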